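Ortho fluoro for chloro in the arylidene thiazolidinone series

This account rests on a few compounds, and the source may have more. Where it says the series, first, only, none or still open, it means among the compounds named here.

Compound 1 `O=C1NC(=S)/C(=C/c2cccc(Cl)c2)S1` gives 21.6% in a functional assay on NCI-H292 cells (Homo sapiens) for cytotoxicity, read by MTT assay, with a stated time of 72 h, tested at 5 ug/mL; a higher number here means more inhibition of growth at the concentration tested, a lower number less inhibition of growth. Compound 2 `O=C1NC(=S)/C(=C/c2ccccc2Cl)S1`, whose core holds the same atoms joined differently, gives 34.2% in this assay, the highest of the three measured values; the difference between the two cores is not broken down here. Compound 3 `O=C1NC(=S)/C(=C/c2cccc(F)c2)S1` gives 13.1% in this assay. The change from compound 1 to compound 3 is fluoro in place of chloro on an aromatic carbon, and it made the step of a number 8.5 percentage points lower from compound 1 to compound 3 (within the scatter). Compound 4 `O=C1NC(=S)/C(=C/c2ccccc2F)S1` is not yet measured; its change from compound 2 is fluoro in place of chloro on an aromatic carbon, the same kind of change as that from compound 1 to compound 3, but ortho to a group of 8 heavy atoms rather than meta to a group of 8 heavy atoms. For the measured compounds named here, the step from compound 2 to compound 4 in this assay is expected to be a number 8.2 percentage points lower from compound 2 to compound 4 (within the scatter), small, because a number 8.5 percentage points lower from compound 1 to compound 3 (within the scatter) is the only measured instance of this kind of change. Compound 4 is estimated at 26% in this assay, expected to fall between 13% and 39%.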

Compound 4, percent growth inhibition at one concentration: 25.2%
Beside the measured number, compound 4's estimate is 0.8 percentage points above it, and the stated range covers the measured number.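

Fluoro in place of chloro on an aromatic carbon gives a number 9 percentage points lower from compound 2 to compound 4 (within the scatter) in this assay. Set beside the earlier step, the change carries from one core to the other with no detectable difference: the same change on two cores in this assay, a number 8.5 percentage points lower (within the scatter) from compound 1 to compound 3 and a number 9 percentage points lower (within the scatter) from compound 2 to compound 4, 0.5 percentage points apart, within the scatter of two such steps. For the compounds shown here, this shows only that the two steps agree; each lies within the scatter on its own, so neither establishes a real effect of the change, and two pairs make no rule for the wider series.

The compounds shown leave open how other groups on the aromatic ring would read, such as bromo, an amine, a carboxylic acid or a methoxy group. Also open, as far as these compounds go, is whether the agreement holds in other cell lines.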